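The source may report more compounds than this note shows. Statements on the series, on what has been measured and on what is new or still open speak of the compounds shown alone.

Measured so far in a physicochemical assay for solubility; a lower number here means a less soluble compound, a higher number a more soluble compound:
- Compound 1 `CNC(=O)c1cc(C(=O)N[C@H]2[C@@H]3COC[C@@H]32)cc2c1OC[C@H]2c1cccnc1`: >= 104 ug/mL, a limit of the assay
- Compound 2 `CNC(=O)c1cc(C(=O)Nc2cnn(C)c2)cc2c1OC[C@H]2c1ccccc1`: >= 189 ug/mL, a limit of the assay

In this assay, compound 1 stands only on a limit, >= 104 ug/mL, and not on a number. Compound 2 also has only a limit, >= 189 ug/mL. The two compounds therefore cannot be placed in order.

The next compound, compound 3 `CNC(=O)c1cc(C(=O)N[C@H]2[C@@H]3COC[C@@H]32)cc2c1OC[C@H]2c1ccccn1`, keeps the core of compound 1 and differs in one place, on a saturated ring carbon of a five-membered non-aromatic ring. There, pyridin-2-yl stands in place of pyridin-3-yl (pyridin-2-yl in place of pyridin-3-yl on a saturated ring carbon). The two have the same atoms, joined differently. Among the measured compounds shown here, no pair of measured compounds shows what this change does, so there is no measured step to go by, and no direction can be given. The change in this assay is expected to be none beyond the scatter. The estimated step that the limit leaves unreadable from compound 1 to compound 3 rests on compound 1 alone. Compound 3 may well be reported only as a limit too. Compound 3 is estimated at 120 ug/mL, with an expected range from 55 ug/mL to 210 ug/mL.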

Compound 3, solubility: >= 158 ug/mL
Compound 3 ended at the assay's limit; the forecaster's own chance of this, stated with the estimate: 65%; middle value at least 1.3-fold (0.11 log units) away from the limit.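

In this assay, among the compounds shown here, compound 1 and compound 3 both stand only on limits of the assay, and no step between them can be read. The compounds shown leave open whether pyridin-2-yl in place of pyridin-3-yl on a saturated ring carbon changes this read-out at all, and in which direction.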